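The compounds below may be only part of what the source reports. "The series", "measured", "known", "first", "only" and "open" are said of these compounds alone.

In a functional assay on QGY7701 cells (Homo sapiens) for cytotoxicity, read by MTT assay, with a stated time of 24 h (a lower number here means a stronger inhibitor, a higher number a weaker inhibitor), compound 1 `C=CC1=C(C(=O)NCC(C)C)C(c2ccc(OC)cc2)OC1` gives only a limit, > 100000 nM. Compound 2 `C=CC1=C(C(=O)NCc2ccc(OC)c(OC)c2)C(c2ccc(OC)cc2)OC1` likewise gives only a limit in this assay, > 100000 nM. Both results sit at the limit of > 100000 nM in this assay, at which 2 of the 2 values shown sit, and compound 2 stands exactly where compound 1 stands, with no number below that limit for either. Compound 3 `C=CC1=C(C(=O)NCc2ccc(OC)c(OC)c2)C(c2ccc(F)cc2)OC1` is not yet measured. It differs from compound 2 by fluoro in place of methoxy on an aromatic carbon. No measured step of this kind exists among these compounds. The step from compound 2 to compound 3 is expected to be a step that the limit leaves unreadable from compound 2 to compound 3, none beyond the scatter. Compound 3 is therefore expected to give about 150000 nM, between 50000 nM and 500000 nM, most likely reported once more as a limit.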

Compound 3, half-maximal inhibitory concentration: 87300 nM
For compound 3 the middle estimate is 1.7-fold (0.24 log units) above the measured one, and the stated range covers the measured number.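

In this assay, among these compounds, compound 3 gives 87300 nM, the only value here that is a number rather than a limit. At this position, on the ring para to a large group, fluoro in place of methoxy gives an at least 1.1-fold lower number from compound 2 to compound 3 (0.05 log units; that floor lies within the scatter). Compound 2 has only a limit, so that figure is a floor and the true size of the change stays unread: the limit of > 100000 nM in this assay, at which 2 of the 3 values shown sit.

Still open, on these data alone, is whether another group at this position, such as an amine or a hydroxyl, would bring the number lower. Among the compounds shown here, also open is whether fluoro would give a measurable number alongside the other amide side chain, the one in compound 1.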